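The source may hold more compounds than are shown below. What is called first, only, known or untested is meant among the compounds shown, and "the series" means these compounds.

Measured in a functional assay on HT-29 cells (Homo sapiens) for cytotoxicity, read by sulforhodamine B assay, with a stated time of 72 h; a lower number here means a stronger inhibitor, a higher number a weaker inhibitor:
- compound 1 `CCCCC/C=C\C[C@]1(O)C=CC(=O)/C1=C/C=C/CCCC(=O)OC`: 4100 nM
- compound 2 `CCCCC/C=C\C[C@]1(O)C=CC(=O)/C1=C\C=C\CCCC(=O)OC`: 7900 nM
- compound 3 `CCCCC/C=C\C[C@@]1(O)C=C(I)C(=O)/C1=C/C=C/CCCC(=O)OC`: 6500 nM

Compound 3, at 6500 nM, lies within the scatter of both compound 1 and compound 2. Compound 4 `CCCCC/C=C\C[C@@]1(O)C=C(Br)C(=O)/C1=C/C=C/CCCC(=O)OC` differs from compound 3 by bromo in place of iodo on a double-bonded ring carbon, with bromo in place of iodo on a double-bonded ring carbon. Among the measured compounds shown here, the only measured step is a 1.9-fold higher number from compound 1 to compound 2 (0.28 log units; within the scatter). For the measured compounds named here, it rests on (the fact that compounds 1 and 2 differ only in the configuration as drawn), so it bears only weakly on this exchange, and no measured step involves either group. No shift beyond the scatter is therefore expected in this assay. The estimated step is a 1.2-fold lower number from compound 3 to compound 4 (0.07 log units; within the scatter), with no firm direction. For compound 4 the expected value is 5500 nM, with an estimated range of 2700 nM to 11000 nM.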

Compound 4, half-maximal inhibitory concentration: 5400 nM
Compound 4: the middle estimate sits 1.0-fold (0.01 log units) above what was measured, within the range that was stated.
By their numbers in this assay, from the lowest: compounds 1, 4, 3 and 2 (each within the scatter of the next).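

At the double-bonded ring carbon, bromo in place of iodo gives a 1.2-fold lower number from compound 3 to compound 4 (0.08 log units; within the scatter) in this assay. Among the compounds shown here, this is the first exchange read at this position, and the two halogens are not told apart there in this assay. Nothing available bears on a cause for this result.

Going by these compounds, whether an amine or a nitrile on the same carbon would move the number beyond the scatter remains open. Also open, on these data alone, is whether a carboxylic acid there would do so.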